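Carbonyl substituent variation on the shared core

This account rests on a few compounds, and the source may have more. Where it says the series, first, only, none or still open, it means among the compounds named here.

Of the compounds shown here, three sharing one core have been measured in a functional assay for inhibition of nuclear factor NF-kappa-B complex (Homo sapiens); on this read-out higher numbers stand for weaker inhibition and lower numbers for stronger inhibition. Compound 1 `COc1ccc2c(c1)OC(c1cc(OC)c(OC)c(OC)c1)C(C(=O)OC(C)C)=C2` gives 11800 nM. Compound 2 `COc1ccc2c(c1)OC(c1cc(OC)c(OC)c(OC)c1)C(C(=O)N(C)OC)=C2` gives 11700 nM. Compound 3 `COc1ccc2c(c1)OC(c1cc(OC)c(OC)c(OC)c1)C(C=O)=C2` gives 13500 nM. Compound 3 stands alongside the other two: a 1.1-fold higher number from compound 1 to compound 3 (0.06 log units; within the scatter) and a 1.2-fold higher number from compound 2 to compound 3 (0.06 log units; within the scatter), so all three numbers lie within the scatter of one another, and nothing separates them.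

Compound 4 `COC(=O)C1=Cc2ccc(OC)cc2OC1c1cc(OC)c(OC)c(OC)c1` is not yet measured. It differs from compound 3 by methoxy in place of hydrogen on a carbonyl carbon. Among the measured compounds shown here, the steps that bear on this change are those at the same carbonyl carbon: a 1.1-fold higher number from compound 1 to compound 3 (0.06 log units; within the scatter) and a 1.2-fold higher number from compound 2 to compound 3 (0.06 log units; within the scatter), which show that exchanging isopropoxy or methoxy(methyl)amino for hydrogen at this position left the read-out unchanged within the scatter. Bringing methoxy in at the same place is therefore expected to give no step beyond the scatter, in either direction; the expected step is a 1.1-fold lower number from compound 3 to compound 4 (0.05 log units; within the scatter). Compound 4 is estimated at 12000 nM, with a range from 6000 nM to 25000 nM.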

Compound 4, half-maximal inhibitory concentration: 13800 nM
Compound 4: middle estimate off by 1.2-fold (0.06 log units), on the low side; the measured number falls inside the stated range.
By their numbers in this assay, from the lowest: compounds 2, 1, 3 and 4 (each within the scatter of the next).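

The new ester extends the flat picture in this assay to a fourth group on this carbonyl carbon: formyl to methoxycarbonyl gives a 1.0-fold higher number from compound 3 to compound 4 (0.01 log units; within the scatter) and so opens no gap. Among the compounds shown here, the same holds for methoxy in place of methoxy(methyl)amino, which gives a 1.2-fold higher number from compound 2 to compound 4 (0.07 log units; within the scatter) as its step, and for the first direct comparison of two esters, where methyl in place of isopropyl gives a 1.2-fold higher number from compound 1 to compound 4 (0.07 log units; within the scatter) as its step. No evidence is available to account for this lack of separation among the four compounds.

On these data alone, whether a carboxylic acid, a primary amide or an ester with a longer chain at this carbonyl carbon would give a step beyond the scatter remains open. All four compounds also keep the rest of the shared core unchanged, so they say nothing about the effect of changes elsewhere.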